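Imine variation on a doubly benzyloxy-substituted core

The compounds below may be only part of what the source reports. "The series", "measured", "known", "first", "only" and "open" are said of these compounds alone.

Measured so far:
compound 1 `O=c1cc(/C=N\c2ccc(O)cc2)c2ccc(OCc3ccccc3)cc2o1` — 64500 nM
compound 2 `N/N=C\c1cc(=O)oc2cc(OCc3ccccc3)cc(OCc3ccccc3)c12` — 363000 nM

Both numbers come from a functional assay, read by spectrophotometry, with a stated time of 3 min; a higher number here means a weaker inhibitor, a lower number a stronger inhibitor. Compound 2 has the highest number of the two; the nearest is compound 1, whose number is lower by a margin that lies beyond the usual scatter. Compound 2 and compound 1 differ in more than one place, so their gap cannot be split into single steps.

Compound 3 `O=c1cc(/C=N\c2ccc(O)cc2)c2c(OCc3ccccc3)cc(OCc3ccccc3)cc2o1` is not yet measured. It is compound 2 with 4-hydroxyphenyl in place of amino on a double-bonded nitrogen. With that change, compound 3 carries the same imine side as compound 1, set on the core of compound 2.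

Among the compounds with values here, no measured pair isolates this change. Compound 1, which carries the 4-hydroxyphenyl rather than the amino, stands well below compound 2 in this assay, so the change is expected to lower the number beyond the scatter. The step from compound 2 to compound 3 is estimated at a 4.5-fold lower number from compound 2 to compound 3 (0.66 log units; beyond the scatter). Compound 3 is estimated at 80000 nM, with a range from 20000 nM to 300000 nM.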

Compound 3, half-maximal inhibitory concentration: 3570 nM
Beside the measured number, compound 3's estimate is 22-fold (1.35 log units) above it; the measured number lies below the stated range.
By their numbers in this assay, from the lowest: compound 3; then compound 1; then compound 2.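

In this assay, the series now has its first comparisons that differ in one place. On the double-bonded nitrogen of the compound 2 core, 4-hydroxyphenyl in place of amino gives a 100-fold lower number from compound 2 to compound 3 (2.01 log units; beyond the scatter), showing that this position responds strongly to the group it carries, at least for these two groups. With the imine side held constant, benzyloxy in place of hydrogen on an aromatic carbon gives an 18-fold lower number from compound 1 to compound 3 (1.26 log units; beyond the scatter), so the core substitution also has a large effect, and compound 3 stands lowest of the three, with both steps beyond the scatter. No measurement available here explains either step.

From the compounds shown here alone, each change is seen only once, so it remains open whether the nitrogen step would keep its size on the core of compound 1, and whether the hydroxyl of the 4-hydroxyphenyl matters, which a plain phenyl or a 4-methoxyphenyl on the same nitrogen would test. Also open, going by these compounds, is whether the benzyloxy step depends on the benzyl part, which a methoxy group on that aromatic carbon would test.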